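Tert-butoxycarbonyl removal on the amine chain: compound 4

This account rests on a few compounds, and the source may have more. Where it says the series, first, only, none or still open, it means among the compounds named here.

Measured so far:
Compound 1, `COC(=O)CC1c2ccccc2N=C(NCCCCCN)N1c1ccc(-c2ccccc2)cc1`, gives 82.5% in an assay on HEK293 cells for inhibition of Voltage-dependent T-type calcium channel subunit alpha-1G (Homo sapiens), tested at 10 uM; a lower number here means less inhibition, a higher number more inhibition at the concentration tested (going by the name of the read-out).
Compound 2, `COC(=O)CC1c2ccccc2N=C(NCCCCCNC(=O)OC(C)(C)C)N1c1ccc(-c2ccccc2)cc1`, gives 86.5% in this assay.
Compound 3, `COC(=O)CC1c2ccccc2N=C(Nc2ccc(-c3ccccc3)cc2)N1CCCCCNC(=O)OC(C)(C)C`, gives 88.5% in this assay.

Compound 2 and compound 1 differ only in hydrogen in place of tert-butoxycarbonyl on an amine nitrogen. That change gives a number 4 percentage points lower from compound 2 to compound 1 (within the scatter), so the read-out is essentially unmoved by it. Compound 3 is built from the same atoms as compound 2, joined differently; the difference between the two cores is not broken down here. Compound 3 stands within the scatter of compound 2, and also within the scatter of compound 1, so no order among the three measured compounds can be read from this assay.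

Compound 4, `COC(=O)CC1c2ccccc2N=C(Nc2ccc(-c3ccccc3)cc2)N1CCCCCN`, has not been measured. It stands to compound 3 as compound 1 stands to compound 2: the change is hydrogen in place of tert-butoxycarbonyl on an amine nitrogen, at a place described in the same words as in the earlier pair, so it is the same change. Within the data shown here, the only guide is the step from compound 2 to compound 1, which lay within the scatter.

The expected step for compound 4 is therefore a number 4 percentage points lower from compound 3 to compound 4 (within the scatter), resting on a number 4 percentage points lower from compound 2 to compound 1 (within the scatter) seen for compound 1. Compound 4 is expected to give about 84.5% in this assay, with a likely range from 72% to 95%. A single earlier pair is a thin basis, so the range is kept wide.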

Compound 4, a percentage reported as inhibition, at one concentration (the size of the read-out at that concentration, not a potency): 84.1%
Compound 4: the middle estimate sits 0.4 percentage points above what was measured; the measured number falls inside the stated range.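

In this assay, hydrogen in place of tert-butoxycarbonyl on an amine nitrogen gives a number 4.4 percentage points lower from compound 3 to compound 4 (within the scatter), and set beside the earlier pair the change reads the same on both cores: the same change on two cores in this assay, a number 4 percentage points lower (within the scatter) from compound 2 to compound 1 and a number 4.4 percentage points lower (within the scatter) from compound 3 to compound 4, 0.4 percentage points apart, within the scatter of two such steps

Within these two pairs, then, the change carries from one core to the other without the read-out separating them, and the free amine and the tert-butoxycarbonyl-protected amine cannot be told apart on either core. Among these compounds, this does not show that a change with a real effect would transfer in the same way, since both steps lie within the scatter and the agreement is between two steps that cannot be told from no step at all; a read-out at one concentration also says nothing about potency on either core.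

The compounds shown leave open whether a carboxylic acid in place of the amine, or a shorter or longer chain, would move the read-out beyond the scatter on either core. Also open, on these data alone, is whether the two cores would separate in a full potency measurement rather than at a single concentration.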